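Swapping the Amide Substituent on a Shared Core

The source may report more compounds than this note shows. Statements on the series, on what has been measured and on what is new or still open speak of the compounds shown alone.

Compound 1 `O=C(Nc1ccccn1)c1c(O)c2cccnc2n(-c2ccccc2)c1=O` gives 14.6% in a functional assay on the whole organism for inhibition, with Rattus norvegicus as the target, read by cytopathic effect and paw edema, at a dose of 100 mg/kg by the oral route; a lower number here means less inhibition, a higher number more inhibition at the dose given (going by the name of the read-out).
Compound 2 `O=C(NN1CCOCC1)c1c(O)c2cccnc2n(-c2ccccc2)c1=O` gives -26.2%.
Compound 3 `O=C(Nc1ccc([N+](=O)[O-])cc1)c1c(O)c2cccnc2n(-c2ccccc2)c1=O` gives -25.8%.

Compound 2 sits at the bottom of the numbers shown, though compound 3 cannot be told apart from it within the scatter, while compound 1 lies well above. Compound 4 `Cc1cnccc1NC(=O)c1c(O)c2cccnc2n(-c2ccccc2)c1=O` is not yet measured and differs from compound 2 in one place: 3-methylpyridin-4-yl in place of morpholin-4-yl on an amide-type nitrogen. Among the measured compounds shown here, two measured steps bear on this. a number 40.8 percentage points lower from compound 1 to compound 2 (beyond the scatter) shows that exchanging pyridin-2-yl for morpholin-4-yl lowered inhibition sharply, so the reverse kind of change may raise it. Yet a number 0.4 percentage points higher from compound 2 to compound 3 (within the scatter) shows that an aromatic ring without a pyridine nitrogen did not. Because compound 1 gives 14.6% with a pyridine ring on the amide-type nitrogen and compound 4 carries a pyridine ring again, a moderate rise is expected, namely a number 31.2 percentage points higher from compound 2 to compound 4 (beyond the scatter). Compound 4 is therefore estimated at 5%, between -20% and 30%.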

Compound 4, a percentage reported as inhibition, in the whole organism at one dose (the size of the read-out at that dose, not a potency): 8.8%
Compound 4: middle estimate off by 3.8 percentage points, on the low side; the range from low to high includes it.
By their numbers in this assay, from the lowest: compounds 2 and 3 (each within the scatter of the next); then compounds 4 and 1 (each within the scatter of the next).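

Exchange for 3-methylpyridin-4-yl on the amide-type nitrogen gives a number 35 percentage points higher from compound 2 to compound 4 (beyond the scatter) and a number 34.6 percentage points higher from compound 3 to compound 4 (beyond the scatter) in this assay, so the rise appears against two quite different groups. Set against the other pyridine, a number 5.8 percentage points lower from compound 1 to compound 4 (within the scatter) leaves 3-methylpyridin-4-yl and pyridin-2-yl indistinguishable here. Among these four compounds, then, both pyridine-bearing compounds stand clear of the morpholin-4-yl and 4-nitrophenyl compounds.

Going by these compounds, whether a plain phenyl ring or a dimethylamino group would fall with the pyridines remains open. What separates the pyridine rings from the other groups also stays unexplained, with no supporting measurement available.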